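This account rests on a few compounds, and the source may have more. Where it says the series, first, only, none or still open, it means among the compounds named here.

For the measured compounds named here, in a functional assay on HCT-116 cells (Homo sapiens) for antiproliferative activity, read by MTT assay, with a stated time of 48 h (on this read-out lower numbers stand for stronger inhibition and higher numbers for weaker inhibition), compound 1 `COc1ccc(N(C)c2ccnc(Cl)n2)cc1F` gives 914 nM, the lowest of the three numbers measured so far. Compound 2 `COc1ccc(N(C)c2ccnc(Cl)n2)cc1OCCBr` gives 5670 nM, and compound 3 `COc1ccc(N(C)c2ccnc(Cl)n2)cc1OCCCBr` gives 1970 nM. The next structure, compound 4 `COc1ccc(N(C)c2ccnc(Cl)n2)cc1OCCCCCBr`, keeps the core of compound 1 but carries (5-bromopentyl)oxy in place of fluoro on an aromatic carbon.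

Two measured steps make the same kind of swap. With 2-bromoethoxy the change is a 6.2-fold higher number from compound 1 to compound 2 (0.79 log units; beyond the scatter), and with 3-bromopropoxy it is a 2.2-fold higher number from compound 1 to compound 3 (0.33 log units; beyond the scatter). Both are modest and both point towards weaker inhibition. Between those two chains the change is a 2.9-fold lower number from compound 2 to compound 3 (0.46 log units; beyond the scatter), so the number falls as the chain goes from 2-bromoethoxy to 3-bromopropoxy. That trend rests on a single pair, however, and nothing measured yet shows how a (5-bromopentyl)oxy chain behaves.

The nearest guide is compound 3 at 1970 nM, so a modest rise from compound 1, similar in size to that step, seems most likely. The step expected in this assay is a 2.2-fold higher number from compound 1 to compound 4 (0.34 log units; beyond the scatter). Compound 4 is estimated at 2000 nM, with an expected range from 700 nM to 5500 nM.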

Compound 4, half-maximal inhibitory concentration: > 10000 nM
Compound 4: only a limit was reported; the forecaster's own chance of this, stated with the estimate: 5%; middle value at least 5.0-fold (0.69 log units) away from the limit.
By their numbers in this assay, from the lowest: compound 1; then compound 3; then compound 2. At a limit, above all of these: compound 4.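

In this assay compound 4 is reported only as a limit, not as a number: the limit of > 10000 nM in this assay, at which 1 of the 4 values shown sits.

Even so, swapping fluoro for (5-bromopentyl)oxy at this aromatic carbon gives the largest step seen at this position, an at least 10-fold higher number from compound 1 to compound 4 (1.03 log units; beyond the scatter), so a chain here can cost much more than the modest earlier steps suggested. The fall in the number from 2-bromoethoxy to 3-bromopropoxy does not carry on as the chain grows: the (5-bromopentyl)oxy chain brings an at least 5.0-fold higher number from compound 3 to compound 4 (0.70 log units; beyond the scatter), while the comparison with the shorter 2-bromoethoxy chain gives only an at least 1.7-fold higher number from compound 2 to compound 4 (0.24 log units; that floor lies within the scatter), so the order of those two cannot be settled.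

Every chain shown ends in bromine, so it remains open whether this weak result follows from chain length alone or from the chain and its bromine together, a question that a plain pentyloxy chain or a chain ending in an amine would address. It is also unclear how a 4-bromobutoxy chain would behave, and whether the rise in the number sets in gradually or abruptly with chain length.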